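The compounds below may be only part of what the source reports. "The series", "measured", "known", "first", "only" and "open" are said of these compounds alone.

Compound 1 `CN(CCNCc1cn(-c2ccccc2)nn1)CCNc1ccnc2cc(Cl)ccc12` is tested in a functional assay on HCC827 cells (Homo sapiens) for antiproliferative activity, read by sulforhodamine B assay, with a stated time of 72 h (a higher number here means a weaker inhibitor, a lower number a stronger inhibitor), and gives 26000 nM, the second highest of the three numbers. Its neighbours are compound 2 `CN(CCNCc1cn(Cc2ccc(Br)cc2)nn1)CCNc1ccnc2cc(Cl)ccc12`, which gives 9300 nM, and compound 3 `CN(CCNCc1cn(Cc2nc3ccccc3[nH]2)nn1)CCNc1ccnc2cc(Cl)ccc12`, which gives 164000 nM; the step of a 2.8-fold lower number from compound 1 to compound 2 (0.45 log units; beyond the scatter) is modest, while a 6.3-fold higher number from compound 1 to compound 3 (0.80 log units; beyond the scatter) is larger and in the other direction.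

Compound 4 `CN(CCNCc1cn(-c2nc3ccccc3[nH]2)nn1)CCNc1ccnc2cc(Cl)ccc12` differs from compound 1 as follows: 1H-benzimidazol-2-yl in place of phenyl on an aromatic nitrogen.

The step that bears on this is a 6.3-fold higher number from compound 1 to compound 3 (0.80 log units; beyond the scatter), where the same benzimidazole group entered through a saturated chain carbon. Compound 4 attaches it directly, so a weakening of a similar size is expected, a 3.8-fold higher number from compound 1 to compound 4 (0.59 log units; beyond the scatter). The estimate for compound 4 is 100000 nM, with a range from 35000 nM to 300000 nM.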

Compound 4, half-maximal inhibitory concentration: 32000 nM
The estimate for compound 4 lay 3.1-fold (0.49 log units) above the measured number, outside the stated range (below it).
By their numbers in this assay, from the lowest: compound 2; then compounds 1 and 4 (each within the scatter of the next); then compound 3.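

On this aromatic nitrogen, 1H-benzimidazol-2-yl and phenyl cannot be told apart, with a 1.2-fold higher number from compound 1 to compound 4 (0.09 log units; within the scatter) as the step. The benzimidazole group therefore does not by itself weaken the compound: removing the saturated carbon link gives a 5.1-fold lower number from compound 3 to compound 4 (0.71 log units; beyond the scatter) as the step, while compound 2 still gives the lowest number, with a 3.4-fold higher number from compound 2 to compound 4 (0.54 log units; beyond the scatter) as the step. Nothing measured here explains these differences. Still open, on these data alone, is how a 4-bromophenyl directly on this nitrogen, or a longer chain between the nitrogen and the benzimidazole, would compare.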